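The compounds below may be only part of what the source reports. "The series", "measured", "known", "first", "only" and "open" are said of these compounds alone.

Series notes. Compound 1 `CC(C)c1c(C(=O)N(C)Cc2ccccc2)nn(-c2ccc(F)cc2)c1OC[C@@H](O)C[C@@H](O)CC(=O)O` gives 5.2 nM in an assay on microsomes from liver for inhibition of 3-hydroxy-3-methylglutaryl-coenzyme A reductase (Rattus norvegicus); a lower number here means a stronger inhibitor, a higher number a weaker inhibitor. Compound 2 `Cc1ccc(CNC(=O)c2nn(-c3ccc(F)cc3)c(OC[C@@H](O)C[C@@H](O)CC(=O)O)c2C(C)C)cc1` gives 15 nM in this assay. Compound 3 `CC(C)c1c(C(=O)NCc2ccccn2)nn(-c2ccc(F)cc2)c1OC[C@@H](O)C[C@@H](O)CC(=O)O` gives 25 nM in this assay, the highest of the three numbers; the step of a 4.8-fold higher number from compound 1 to compound 3 (0.68 log units; beyond the scatter) lies beyond the scatter, whereas a 1.7-fold higher number from compound 2 to compound 3 (0.22 log units; within the scatter) stays within it. Compound 4 `CC(C)c1c(C(=O)NCc2ccccc2Cl)nn(-c2ccc(F)cc2)c1OC[C@@H](O)C[C@@H](O)CC(=O)O` carries 2-chlorophenyl in place of pyridin-2-yl on a saturated chain carbon bound to an amide-type nitrogen. The comparison that bears most directly on it is a 1.7-fold higher number from compound 2 to compound 3 (0.22 log units; within the scatter), which swapped one six-membered aromatic ring for another at the same place and moved the number little; the modest 2.9-fold higher number from compound 1 to compound 2 (0.46 log units; beyond the scatter) and a 4.8-fold higher number from compound 1 to compound 3 (0.68 log units; beyond the scatter) change the whole amide substituent rather than the ring alone. The expected step of a 1.7-fold lower number from compound 3 to compound 4 (0.22 log units; within the scatter) for compound 4 is therefore small, with no direction beyond the scatter. Compound 4 is estimated at 15 nM, within 6 nM to 40 nM.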

Compound 4, half-maximal inhibitory concentration: 9.5 nM
The estimate for compound 4 lay 1.6-fold (0.20 log units) above the measured number, and the stated range covers the measured number.
By their numbers in this assay, from the lowest: compounds 1, 4, 2 and 3 (each within the scatter of the next, the first and the last beyond it).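

In this assay, the ring on the saturated chain carbon bound to an amide-type nitrogen now gives a step beyond the scatter (a 2.6-fold lower number from compound 3 to compound 4 (0.42 log units; beyond the scatter)) with 2-chlorophenyl in place of pyridin-2-yl, while 2-chlorophenyl and 4-methylphenyl stay within it (a 1.6-fold lower number from compound 2 to compound 4 (0.20 log units; within the scatter)). Unlike compounds 2 and 3, compound 4 also stays within the scatter of the benzyl(methyl)amino amide (a 1.8-fold higher number from compound 1 to compound 4 (0.26 log units; within the scatter)). No measurement shown accounts for these steps. As far as these compounds go, whether unsubstituted phenyl, 4-chlorophenyl or pyridin-3-yl at this place would fall with compound 4 or with compound 3 stays open.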